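A few compounds are considered here, and "the series" means these few. Any claim that something is new, unique, unknown or untested is made for them only; others in the source may bear on it.

Of the compounds shown here, two have so far been tested in a functional assay on A549 cells (Homo sapiens) for inhibition, read by CCK-8 assay, with a stated time of 72 h, tested at 10 uM; on this read-out lower numbers stand for less inhibition of growth and higher numbers for more inhibition of growth at the one concentration tested. Compound 1 `Nc1ccc(NC(=O)C2(C(=O)Nc3ccc(F)cc3)CC2)cc1F` gives 14.6% in this assay. Compound 2 `CN(C)C(=O)c1cc2cnc(Nc3ccc(NC(=O)C4(C(=O)Nc5ccc(Cl)c(C(F)(F)F)c5)CC4)cc3)nc2n1C1CCCC1`, a far larger molecule, gives 88.1% in this assay, the higher of the two numbers, with compound 1 lying far below it, beyond the usual scatter. The next compound, compound 3 `CN(C)C(=O)c1cc2cnc(Nc3ccc(NC(=O)C4(C(=O)Nc5ccccc5)CC4)cc3)nc2n1C1CCCC1`, keeps all of compound 2 except for one change: phenyl in place of 4-chloro-3-(trifluoromethyl)phenyl on an amide-type nitrogen. Going by the values given here, no pair of measured compounds differing in exactly one place is available, so the size of this step cannot be read from data. Among the compounds with values here, because the only high number belongs to compound 2 at 88.1% and compound 3 lacks its chloro and trifluoromethyl groups, a loss is expected. The step is expected to be a number 33.1 percentage points lower from compound 2 to compound 3 (beyond the scatter) in this assay. Compound 3 is therefore estimated at 55% in this assay, within a range from 25% to 80%.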

Compound 3, percent growth inhibition at one concentration: 88.8%
Compound 3: middle estimate off by 33.8 percentage points, on the low side; measured number above the stated range.
By their numbers in this assay, from the lowest: compound 1; then compounds 2 and 3 (each within the scatter of the next).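

Swapping 4-chloro-3-(trifluoromethyl)phenyl for phenyl on the amide-type nitrogen gives a number 0.7 percentage points higher from compound 2 to compound 3 (within the scatter) in this assay, the first comparison of two compounds that differ in one place only. At this position and this single concentration, the chloro and trifluoromethyl groups are therefore not needed for a high number, and unsubstituted phenyl reads the same within the scatter. No measurement shown accounts for this result.

Still open, from the compounds shown here alone, is whether a phenyl ring is needed on this nitrogen at all, or whether a cyclohexyl or methyl group, or a phenyl carrying an amine or a carboxylic acid, would read alike. Also open, going by these compounds, is whether compound 2 and compound 3 would remain indistinguishable at lower concentrations, and how changes elsewhere on the shared core would act.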